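The source may hold more compounds than are shown below. What is called first, only, known or untested is meant among the compounds shown, and "the series" means these compounds.

Measured so far in an assay on microsomes from brain for inhibition of Fatty-acid amide hydrolase 1 (Rattus norvegicus), read by fluorescence and HPLC, with a stated time of 45 min; a higher number here means a weaker inhibitor, a lower number a stronger inhibitor:
compound 1 `O=C(COc1ccc(Oc2ccccc2)cc1)Cn1ncnn1` gives 8 nM
compound 2 `COCC(=O)Nc1ccc2c(cnn2CC(=O)COc2ccc(Oc3ccccc3)cc2)c1` gives 6300 nM

For the measured compounds named here, compound 2 holds the higher of the two numbers and compound 1 the lower; the two structures differ in more than one place, so no single step connects them. Compound 3 `O=C(COc1ccc(Oc2ccccc2)cc1)Cn1ncc2cc(NC(=O)NC3CCCCC3)ccc21` differs from compound 2 at one position: cyclohexylamino in place of methoxymethyl on a carbonyl carbon. Going by the values given here, no measured pair isolates this change, so its direction is unknown; a step of no more than modest size from compound 2 is expected, estimated as a 1.6-fold lower number from compound 2 to compound 3 (0.20 log units; within the scatter). Compound 3 is expected to give 4000 nM in this assay, with a range from 400 nM to 40000 nM.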

Compound 3, half-maximal inhibitory concentration: 840 nM
Beside the measured number, compound 3's estimate is 4.8-fold (0.68 log units) above it; low and high end bracket the measured number.
By their numbers in this assay, from the lowest: compound 1; then compound 3; then compound 2.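

In this assay, the group on the carbonyl carbon is a position that affects the number: cyclohexylamino in place of methoxymethyl gives a 7.5-fold lower number from compound 2 to compound 3 (0.88 log units; beyond the scatter). This single change brings in a six-membered ring and a hydrogen-bond donor together, so the step cannot be assigned to either one. Nothing available bears on the cause of this step.

Open, on these data alone, is whether the ring or the nitrogen carries the step: cyclohexyl directly on the carbonyl carbon, or methylamino, would separate the two. Also open, as far as these compounds go, is how phenylamino or a longer alkyl chain would compare.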